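Amino for Hydroxy on Two Indoleamine 2,3-Dioxygenase Cores

The source may report more compounds than this note shows. Statements on the series, on what has been measured and on what is new or still open speak of the compounds shown alone.

Of the compounds shown here, three have been measured in an assay on cells for inhibition of Indoleamine 2,3-dioxygenase 1 (Homo sapiens), read by HPLC, with a stated time of 20 min; on this read-out lower numbers stand for stronger inhibition and higher numbers for weaker inhibition. Compound 1 `Oc1ccccc1-n1ccnc1` gives 16000 nM in this assay. Compound 2 `Nc1ccccc1-n1ccnc1` carries amino in place of hydroxy on an aromatic carbon and gives 1300000 nM, a step of an 81-fold higher number from compound 1 to compound 2 (1.91 log units; beyond the scatter). Compound 3 `Oc1ccc(Cl)cc1-c1nnc[nH]1` is the most potent of the three in this assay, at 600 nM; its core differs from that of compound 1, but the difference between the two cores is not broken down here.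

Compound 4 `Nc1ccc(Cl)cc1-c1nnc[nH]1` has not yet been measured. It differs from compound 3 by amino in place of hydroxy on an aromatic carbon. Among the measured compounds shown here, this is the same kind of change as that from compound 1 to compound 2, though the surroundings are not identical: in compound 4 the place is also para to a chloro group, which has no counterpart in compound 2. For the measured compounds named here, with only one earlier instance of the change to go on, the step of an 81-fold higher number from compound 1 to compound 2 (1.91 log units; beyond the scatter) is the sole guide. Compound 4 is therefore expected to show a step of about a 67-fold higher number from compound 3 to compound 4 (1.82 log units; beyond the scatter) in this assay, because the earlier change gave an 81-fold higher number from compound 1 to compound 2 (1.91 log units; beyond the scatter). Compound 4 is estimated at 40000 nM, most likely between 8000 nM and 200000 nM.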

Compound 4, half-maximal inhibitory concentration: 35 nM
Beside the measured number, compound 4's estimate is 1100-fold (3.06 log units) above it, and the stated range ends above it.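

In this assay, amino in place of hydroxy on an aromatic carbon gives a 17-fold lower number from compound 3 to compound 4 (1.23 log units; beyond the scatter), so the change that weakened inhibition on the core of compound 1 strengthens it on the core of compound 3. The two instances run in opposite directions, and the gap between them is larger than the usual scatter allows: the same change on two cores in this assay, an 81-fold higher number (1.91 log units; beyond the scatter) from compound 1 to compound 2 and a 17-fold lower number (1.23 log units; beyond the scatter) from compound 3 to compound 4, 1400-fold (3.14 log units) apart, beyond the scatter of two such steps. This shows that the size and even the direction of this change did not carry from one core to the other here, but two pairs cannot show which difference between the cores is responsible or how the change would behave on any further core.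

The compounds shown do not separate the chloro group from the rest of the core, as none of them pairs the core of compound 3 with hydrogen in its place or the core of compound 1 with a chloro group. Also open, as far as these compounds go, is how a methoxy group or a methylamino group would fare in the place of hydroxy and amino on either core.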